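Furan to thiophene on the amide side chain

The source may hold more compounds than are shown below. What is called first, only, known or untested is meant among the compounds shown, and "the series" means these compounds.

Compound 2 `COc1cc(-c2cc(C(=O)O)c3ccccc3n2)ccc1OCC(=O)NCc1ccco1` carries a (furan-2-yl)methyl group on its amide-type nitrogen. Among the compounds with values here, in a physicochemical assay for lipophilicity, using the shake flask method, in phosphate buffer, measured as octanol-water partition, at pH 7.4 (on this read-out lower numbers stand for lower lipophilicity and higher numbers for higher lipophilicity), compound 2 gives -0.3, the lowest of the two numbers known so far. Within the data shown here, its nearest neighbour is compound 1 `COc1cc(-c2cc(C(=O)O)c3ccccc3n2)ccc1OCC(=O)Nc1ccccc1Cl`, which in this assay gives 1.6; the single step from compound 1 to compound 2 was a number 1.90 log units lower from compound 1 to compound 2 (beyond the scatter), brought about by putting (furan-2-yl)methyl in place of 2-chlorophenyl on the amide-type nitrogen.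

Compound 3 `COc1cc(-c2cc(C(=O)O)c3ccccc3n2)ccc1OCC(=O)NCc1cccs1` differs from compound 2 by thiophen-2-yl in place of furan-2-yl on a saturated chain carbon bound to an amide-type nitrogen. Among the measured compounds shown here, no measured step of this kind exists; the one known step, from compound 1 to compound 2, exchanges the whole group on the nitrogen and therefore bears on the present change only loosely, as a sign that this position moves the read-out. For the exchange of one five-membered ring for another with a different single hetero atom he expects a small rise, a number 0.60 log units higher from compound 2 to compound 3 (beyond the scatter), in this assay. He therefore estimates compound 3 at 0.3 in this assay, with a range from -0.2 to 0.8.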

Compound 3, distribution coefficient: 0
Beside the measured number, compound 3's estimate is 0.30 log units above it, within the range that was stated.
By their numbers in this assay, from the lowest: compounds 2 and 3 (each within the scatter of the next); then compound 1.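

In this assay, the exchange of furan-2-yl for thiophen-2-yl on a saturated chain carbon bound to an amide-type nitrogen amounts to a number 0.30 log units higher from compound 2 to compound 3 (within the scatter) (so this read-out does not tell the two rings apart at this place). With a second five-membered ring on the chain, the large step away from 2-chlorophenyl appears again as a number 1.60 log units lower from compound 1 to compound 3 (beyond the scatter) (alongside the earlier a number 1.90 log units lower from compound 1 to compound 2 (beyond the scatter)), so among these three compounds the gap to compound 1 does not hang on whether the ring carries oxygen or sulfur. Nothing in hand explains these numbers.

The compounds shown leave open whether a benzyl group or a plain phenyl on the amide-type nitrogen would fall with compound 1 or with compound 2 and compound 3, which would help separate the part played by the chlorine from that of the methylene link. A longer chain between the nitrogen and the thiophene, or a dimethylamino group on that chain, also remains to be placed on this read-out.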